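Swapping the Pyridine Substituent on Compound 3

A few compounds are considered here, and "the series" means these few. Any claim that something is new, unique, unknown or untested is made for them only; others in the source may bear on it.

Measured so far in an ADME assay on a cell-free system (plasma, Homo sapiens); a lower number here means a smaller unbound share, a higher number a larger unbound share of the compound:
Compound 1 `CCNC(=O)Nc1nc2cc(-c3ccc(F)nc3)c(=O)n(C)c2s1`: "not determined" (no result reported)
Compound 2 `CCNC(=O)Nc1nc2cc(-c3cccnc3)c(=O)n(C(C)C(=O)O)c2s1`: 0.22
Compound 3 `CCNC(=O)Nc1nc2cc(-c3cncc(F)c3)c(=O)n(C(C)C)c2s1`: 0.1

Of the two numbers available, the lower belongs to compound 3 at 0.1. Compound 2 gives 0.22, and the gap between these two numbers lies beyond the usual scatter. Compound 4 `CCNC(=O)Nc1nc2cc(-c3ccc(C#N)nc3)c(=O)n(C(C)C)c2s1` differs from compound 3 in one place, with 6-cyanopyridin-3-yl in place of 5-fluoropyridin-3-yl on an aromatic carbon. Within the data shown here, no measured pair shows a change of this kind, so the expectation starts from compound 3 at 0.1. The expected step, a 1.2-fold higher number from compound 3 to compound 4 (0.08 log units; within the scatter), is slightly upward and within the scatter. For compound 4 the estimated value in this assay is 0.12, with an expected range of 0.06 to 0.22.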

Compound 4, unbound fraction: 0.04
Compound 4: the middle estimate sits 3.0-fold (0.48 log units) above what was measured; measured number below the stated range.
By their numbers in this assay, from the lowest: compound 4; then compound 3; then compound 2.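

In this assay, among these compounds, the change from 5-fluoropyridin-3-yl to 6-cyanopyridin-3-yl gives a 2.5-fold lower number from compound 3 to compound 4 (0.40 log units; beyond the scatter) and so shows that the unbound share responds to the group at this position, which the earlier compounds, differing in more than one place, could not show. With the isopropyl group held constant, this swap alone moves the value beyond the scatter. No measured evidence here bears on why this step occurs. The compounds shown leave open how an amine or a methoxy group in place of the nitrile on this pyridine would compare.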